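A few compounds are considered here, and "the series" means these few. Any claim that something is new, unique, unknown or untested is made for them only; others in the source may bear on it.

Compound 1 `CC(=O)n1cc(/C=C(/C(=O)O)c2ccccc2)c2cc(OCc3ccccc3)ccc21`: in a functional assay on M14 cells (Homo sapiens) for cytotoxicity, read by MTT assay, with a stated time of 72 h (on this read-out lower numbers stand for stronger inhibition and higher numbers for weaker inhibition), compound 1 sits at the limit > 100000 nM.
Compound 2 `COc1cc(/C(=C\c2cn(C(C)=O)c3ccc(OCc4ccccc4)cc23)C(=O)O)cc(OC)c1OC`: in this assay compound 2 gives 57100 nM.

Compound 1 stands only at a limit of this assay, (the limit of > 100000 nM in this assay, at which 1 of the 2 values shown sits), so no number is known for it. Going to compound 2 brings an at least 1.7-fold lower number from compound 1 to compound 2 (0.24 log units; that floor lies within the scatter). Compound 3 `COc1ccc(Cn2cc(/C=C(/C(=O)O)c3ccccc3)c3cc(OCc4ccccc4)ccc32)cc1` departs from compound 1 in another place: 4-methoxybenzyl in place of acetyl on an aromatic nitrogen. No measured step touches that position, so nothing shown sets a direction, and compound 1 offers only a floor to build on. Compound 3 is therefore expected to remain weak, estimated at 80000 nM with a range from 20000 nM to 300000 nM. That estimate amounts to an expected step of an at least 1.2-fold lower number from compound 1 to compound 3 (0.09 log units; that floor lies within the scatter).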

Compound 3, half-maximal inhibitory concentration: 64500 nM
Beside the measured number, compound 3's estimate is 1.2-fold (0.09 log units) above it, within the range that was stated.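

Among the compounds shown here, the aromatic nitrogen of the shared core, which no earlier step touched, now has a measured change: 4-methoxybenzyl in place of acetyl brings an at least 1.5-fold lower number from compound 1 to compound 3 (0.19 log units; that floor lies within the scatter) in this assay and adds a six-membered aromatic ring. This shows that the larger group on this nitrogen still gives a readable number, but no direction can be claimed from the step. Compound 1 is known only at a limit, so the step remains a floor: the limit of > 100000 nM in this assay, at which 1 of the 3 values shown sits.

Left open is how a plain benzyl or a longer alkyl chain on this nitrogen would read. Also open, on these data alone, is how 3,4,5-trimethoxyphenyl in place of phenyl would read alongside 4-methoxybenzyl.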